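This account rests on a few compounds, and the source may have more. Where it says the series, first, only, none or still open, it means among the compounds named here.

Working notes on a small set of pyridine-linked phenols, all carrying a 4-hydroxyphenyl group on the shared core.

Compound 1 `Oc1ccc(-c2cc(-c3cccc(Cl)c3)nc(-c3cccs3)c2)cc1` gives 5350 nM in a functional assay on T47D cells (Homo sapiens) for cytotoxicity, read by CCK-8 assay and cell counting, with a stated time of 2 days; a higher number here means a weaker inhibitor, a lower number a stronger inhibitor. Compound 2 `Oc1ccc(-c2cc(-c3ccncc3)nc(-c3cccc(Cl)c3)c2)cc1` has no result in this assay, reported as "not determined" (no result reported). Among the compounds with values here, compound 3 `Oc1ccc(-c2cc(-c3ccccc3)nc(-c3ccc(Cl)cc3)c2)cc1` gives 4270 nM in this assay; this is the lower of the two numbers so far, but its gap to compound 1 lies within the scatter, so the two cannot be ranked.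

Compound 4 `Oc1ccc(-c2cc(-c3ccccc3)nc(-c3cccc(Cl)c3)c2)cc1` has not been measured. It differs from compound 3 in one place: 3-chlorophenyl in place of 4-chlorophenyl on an aromatic carbon. Within the data shown here, no measured pair isolates this change. Compound 1, which also bears a 3-chlorophenyl on the shared core, sits within the scatter of compound 3, so little is expected of moving the chlorine. The step from compound 3 to compound 4 in this assay is expected to be a 1.1-fold higher number from compound 3 to compound 4 (0.02 log units; within the scatter), within the scatter, with no clear direction. Compound 4 is therefore estimated at 4500 nM in this assay, in a range from 1800 nM to 11000 nM.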

Compound 4, half-maximal inhibitory concentration: 4790 nM
Compound 4: middle estimate off by 1.1-fold (0.03 log units), on the low side; measured number inside the range.
By their numbers in this assay, from the lowest: compounds 3, 4 and 1 (each within the scatter of the next).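

In this assay, within the data shown here, the first measured pair at this position, with 3-chlorophenyl in place of 4-chlorophenyl next to the ring nitrogen, gives a 1.1-fold higher number from compound 3 to compound 4 (0.05 log units; within the scatter), so the two chlorine placements are not separated in this assay. The second pair, with phenyl in place of thiophen-2-yl on an aromatic carbon, gives a 1.1-fold lower number from compound 1 to compound 4 (0.05 log units; within the scatter), so this swap is not separated either. No available evidence bears on these results.

From the compounds shown here alone, whether an amine or a carboxylic acid on the aryl group at this position would move the number beyond the scatter stays open. Also open is what replacing the 4-hydroxyphenyl group would do, as that group stands unchanged in all compounds shown.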